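Carbamate in place of ester on the side-chain carbonyl

The source may report more compounds than this note shows. Statements on the series, on what has been measured and on what is new or still open speak of the compounds shown alone.

Among the measured compounds shown here, compound 2 `COc1cc(C(=O)N2CCN(C(=O)c3cc(OC)c(OC)c(OC)c3)C(COC(=O)CC(C)(C)C)C2)cc(OC)c1OC` gives 120 nM in a functional assay (Oryctolagus cuniculus) for inhibition of platelet-activating factor receptor (Cavia porcellus) (a higher number here means a weaker inhibitor, a lower number a stronger inhibitor), the lowest of the two numbers so far; compound 1 `CCCCCCCCCC(=O)OCC1CN(C(=O)c2cc(OC)c(OC)c(OC)c2)CCN1C(=O)c1cc(OC)c(OC)c(OC)c1` gives 2820 nM in this assay. For the measured compounds named here, the single measured step, a 24-fold lower number from compound 1 to compound 2 (1.37 log units; beyond the scatter), concerns the chain on this same carbonyl carbon and is the only guide to the place. Compound 3 `COc1cc(C(=O)N2CCN(C(=O)c3cc(OC)c(OC)c(OC)c3)C(COC(=O)NC(C)(C)C)C2)cc(OC)c1OC` differs from compound 2 by (tert-butyl)amino in place of neopentyl on a carbonyl carbon. Going by the values given here, that step changes the chain by one heavy-atom swap rather than by length, so no measured step bears directly on it; for compound 3 the expected change is a 1.3-fold higher number from compound 2 to compound 3 (0.12 log units; within the scatter), within the scatter. The estimate for compound 3 is 160 nM, between 50 nM and 500 nM.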

Compound 3, half-maximal inhibitory concentration: 130 nM
Estimate against measurement, compound 3: 1.2-fold (0.09 log units) above, within the range that was stated.
By their numbers in this assay, from the lowest: compounds 2 and 3 (each within the scatter of the next); then compound 1.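

In this assay, replacing neopentyl with (tert-butyl)amino gives a 1.1-fold higher number from compound 2 to compound 3 (0.03 log units; within the scatter) and so makes no difference beyond the scatter, even though the entering group carries a hydrogen-bond donor that neopentyl lacks. The carbamate also retains the advantage over the nonyl ester, seen as a 22-fold lower number from compound 1 to compound 3 (1.34 log units; beyond the scatter) and beyond the scatter. The data offer no explanation for either step.

Still open, going by these compounds, is whether the amide hydrogen matters, which a methyl on that nitrogen would test. Also open, on these data alone, is whether smaller or ring-bearing groups, such as ethylamino or cyclohexylamino, would fit this carbonyl carbon equally well.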